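The source may report more compounds than this note shows. Statements on the series, on what has been measured and on what is new or still open speak of the compounds shown alone.

Measured compounds:
- Compound 1 `Fc1cccc(C#Cc2nc3c(s2)CN(C2CCOC2)CC3)c1`: in an assay on HEK293 cells for negative allosteric modulation of metabotropic glutamate receptor 5 (Homo sapiens), read by FLIPR, with a stated time of 1 h (a higher number here means a weaker inhibitor, a lower number a stronger inhibitor), compound 1 gives 400 nM.
- Compound 2 `O=C(C1CCC1)N1CCc2nc(C#Cc3ccccc3)sc2C1`: in this assay compound 2 gives 370 nM.
- Compound 3 `O=C(C1CC(F)(F)C1)N1CCc2nc(C#Cc3cccc(F)c3)sc2C1`: in this assay compound 3 gives > 10000 nM, which is a limit of the assay and not a number.

Compound 2 holds the lower of the two numbers given, but compound 1 sits within the scatter of it, so no order between the two can be read. Going by the values given here, the only step measured so far is an at least 25-fold higher number from compound 1 to compound 3 (1.39 log units; beyond the scatter), where the substituent on the ring nitrogen is exchanged; it ends at the limit of > 10000 nM in this assay, at which 1 of the 3 values shown sits.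

Compound 4 `Cc1nc(C(=O)N2CCc3nc(C#Cc4ccccc4)sc3C2)cs1` keeps the amide on the ring nitrogen and the unsubstituted phenyl acetylene of compound 2 and differs only in the acyl group: 2-methyl-1,3-thiazol-4-yl in place of cyclobutyl on a carbonyl carbon. Among the compounds with values here, no measured pair carries this change; the one measured step concerns a different position and does not transfer. The cyclobutylcarbonyl of compound 2 is compatible with a number in the same range as compound 1, and the exchange for a (2-methyl-1,3-thiazol-4-yl)carbonyl is a moderate change of the acyl group. In this assay a step of a 1.6-fold higher number from compound 2 to compound 4 (0.21 log units; within the scatter) is expected, modest and possibly within the scatter. Compound 4 is estimated at 600 nM, in the range 150 nM to 3000 nM.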

Compound 4, half-maximal inhibitory concentration: > 10000 nM
Compound 4: only a limit was reported; the forecaster's own chance of this, stated with the estimate: 10%; at least 16-fold (1.22 log units) between middle value and limit.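

The carbonyl position does not accept every acyl group: with the rest of compound 2 kept, 2-methyl-1,3-thiazol-4-yl in place of cyclobutyl gives an at least 27-fold higher number from compound 2 to compound 4 (1.43 log units; beyond the scatter) in this assay. From the compounds shown here alone, the value of compound 4 is a limit of the assay and not a number, so the full size of this step stays unknown. The earlier step exchanged oxolan-3-yl on the ring nitrogen for an acyl group, whereas here the amide stays on both sides and only the group on the carbonyl carbon changes, and the series reaches the limit a second time: the limit of > 10000 nM in this assay, at which 2 of the 4 values shown sit.

One pair cannot show whether the loss follows the aromatic ring, its nitrogen and sulfur, or its methyl; a phenyl, an unsubstituted 1,3-thiazol-4-yl or a cyclopentyl on the same carbonyl carbon would begin to separate these. Going by these compounds, it also remains open how a smaller acyl group such as acetyl compares with the cyclobutylcarbonyl of compound 2, and whether a fluorine on the phenyl alters the value in this amide.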